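The source may report more compounds than this note shows. Statements on the series, on what has been measured and on what is new or still open speak of the compounds shown alone.

Working notes on a small set of pyrazoline amides tested for inhibition of human topoisomerase 1. Compound 1 `COc1ccccc1C1=NN(C(=O)c2ccc([N+](=O)[O-])o2)C(c2ccc([N+](=O)[O-])cc2)C1` is the starting point; in an assay on isolated protein for inhibition of DNA topoisomerase 1 (Homo sapiens), with a stated time of 30 min, tested at 100 uM (on this read-out higher numbers stand for more inhibition at the one concentration tested (going by the name of the read-out) and lower numbers for less inhibition), compound 1 gives 0%. Two further members share the same type of acyl variation. Compound 2 `COc1ccc(C2CC(c3ccccc3)=NN2C(=O)c2ccco2)cc1` gives 0% in this assay, and compound 3 `COc1ccc(C2CC(c3ccccc3)=NN2C(=O)c2ccncc2)cc1` gives 0% in this assay. Compound 1 therefore stands level with compounds 2 and 3 at the digits shown, within the scatter of the assay.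

The next compound, compound 4 `COc1ccccc1C1=NN(C(=O)c2ccncc2)C(c2ccc([N+](=O)[O-])cc2)C1`, has not yet been measured. It differs from compound 1 as follows: pyridin-4-yl in place of 5-nitrofuran-2-yl on a carbonyl carbon. Within the data shown here, the one measured step that bears on this change is no change at the digits printed from compound 2 to compound 3 (within the scatter), a swap at the same carbonyl carbon that left the read-out unchanged. On that basis no step beyond the scatter is expected in this assay, and compound 1 already sits at the floor of the read-out. The step from compound 1 to compound 4 is expected to be no change at the digits printed from compound 1 to compound 4 (within the scatter). Compound 4 is accordingly estimated at 0%, with a range from -5% to 10%.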

Compound 4, a percentage reported as inhibition, at one concentration (the size of the read-out at that concentration, not a potency): 0%
Beside the measured number, compound 4's estimate shows no gap at the digits printed, within the range that was stated.
By their numbers in this assay, from the lowest: compounds 1, 2, 3 and 4 (each within the scatter of the next).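

In this assay the exchange of 5-nitrofuran-2-yl for pyridin-4-yl on a carbonyl carbon whose other neighbour is the ring amide-type nitrogen shows no change at the digits printed from compound 1 to compound 4 (within the scatter). A flat read-out for a swap at this carbonyl carbon therefore holds on a second pair with different groups on the shared core, and it now includes 5-nitrofuran-2-yl, a group absent from the earlier pair. Neither acyl group on this core gives any inhibition that this read-out can register at the one concentration tested, so the pair cannot rank the two groups.

From the compounds shown here alone, whether an aliphatic amine, a carboxylic acid or a longer alkyl chain on this carbonyl carbon would lift the read-out off the floor remains open. No measurement in hand accounts for the flat read-out.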